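A few compounds are considered here, and "the series" means these few. Any claim that something is new, unique, unknown or untested is made for them only; others in the source may bear on it.

In a functional assay on HCT-8 cells (Homo sapiens) for antiproliferative activity, read by MTT assay, with a stated time of 48 h (on this read-out higher numbers stand for weaker inhibition and lower numbers for stronger inhibition), the measured compounds read:

Compound 1 `C=C(c1cc(OC)c(OC)c(OC)c1)c1ccc(OC)cc1NC(=O)CO`: 40 nM
Compound 2 `C=C(c1ccc(OC)cc1NC(=O)CN(C)C)c1ccc(OC)c2c1OC(C)(C)C=C2`: 690 nM
Compound 3 `C=C(c1cc(OC)c(OC)c(OC)c1)c1ccc(OC)c(O)c1NC(=O)COC`: 280 nM

Compound 3 holds the middle place of these three numbers, below compound 2 and above compound 1. Compound 4 `C=C(c1cc(OC)c(OC)c(OC)c1)c1ccc(OC)c(O)c1NC(=O)CO` is not yet measured in this assay. It differs from compound 3 as follows: hydrogen in place of methyl on an oxygen on a saturated carbon. In words, this is methoxymethyl to hydroxymethyl. No two measured compounds differ in one place alone, so the size of this step is not shown directly. Compound 1 also carries (hydroxymethyl)carbonyl and gives 40 nM, so a moderate fall in the number, just beyond the scatter, is expected. The expected change is a 2.5-fold lower number from compound 3 to compound 4 (0.41 log units; beyond the scatter). For compound 4 the estimated value is 110 nM, with an expected range from 35 nM to 300 nM.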

Compound 4, half-maximal inhibitory concentration: 40 nM
Beside the measured number, compound 4's estimate is 2.8-fold (0.44 log units) above it; the measured number falls inside the stated range.
By their numbers in this assay, from the lowest: compounds 1 and 4 (each within the scatter of the next); then compound 3; then compound 2.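

In this assay, going by these compounds alone, going from methoxymethyl to hydroxymethyl gives a 7.0-fold lower number from compound 3 to compound 4 (0.85 log units; beyond the scatter), the first direct reading of this change, so the methyl on that oxygen counts for much here. Hydroxy in place of hydrogen on the aromatic carbon gives no change at the digits printed from compound 1 to compound 4 (within the scatter), so with hydroxymethyl present, that hydroxy alters nothing. No measurement at hand bears on why the methyl step is this large.

Open, on these data alone, is whether an aminomethyl or ethoxymethyl group would read like hydroxymethyl or like methoxymethyl. Also open, as far as these compounds go, is whether the methoxymethyl step holds without the aromatic hydroxy.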